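The source may hold more compounds than are shown below. What is called first, only, known or untested is meant among the compounds shown, and "the series" means these compounds.

Working notes, cytotoxicity series.

Three compounds of this series have numbers in an ADME assay on Huh-7 cells (Homo sapiens) for cytotoxicity; on this read-out lower numbers stand for higher toxicity in this test and higher numbers for lower toxicity in this test. Compound 1 `Cc1ccccc1-c1nn(-c2ccc(Cl)cc2)cc1CNCCN1CCN(C)CC1` gives 17000 nM there. Compound 2 `CN1CCN(CCCNCc2cn(-c3ccc(C(F)(F)F)cc3)nc2-c2ccc(C(F)(F)F)cc2)CC1` gives 2000 nM in this assay, and compound 3 `CN1CCN(CCNCc2cn(-c3ccc([N+](=O)[O-])cc3)nc2-c2ccc(C(F)(F)F)cc2)CC1` gives 3200 nM. Among these three, compound 1 stands highest, that is, least toxic in this test; the nearest number is that of compound 3, and the gap lies beyond the scatter, while the furthest is that of compound 2, also beyond the scatter. Among the compounds with values here, no pair among compounds 1, 2 and 3 differs in a single place, so the differences between them cannot be tied to one structural change; compounds 2 and 3 carry other aryl groups on both positions of the shared core as well as, for compound 2, a longer linker.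

Compound 4 `Cc1ccccc1-c1nn(-c2ccc(F)c(F)c2)cc1CNCCN1CCN(C)CC1` is not yet measured. Relative to compound 1 it carries 3,4-difluorophenyl in place of 4-chlorophenyl on an aromatic nitrogen. Within the data shown here, no measured pair in this set isolates a change of this kind at that position, so there is no direct precedent to size the step. With the rest of the molecule unchanged, the expectation is a step from compound 1 to compound 4 of a 1.2-fold lower number from compound 1 to compound 4 (0.08 log units; within the scatter), that is, no shift beyond the scatter in either direction. Compound 4 is therefore estimated at 14000 nM in this assay, within a range of 6000 nM to 32000 nM.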

Compound 4, half-maximal cytotoxic concentration: > 20000 nM
Compound 4: no number, only a limit; the forecaster's own chance of this, stated with the estimate: 15%; middle value at least 1.4-fold (0.15 log units) away from the limit.
By their numbers in this assay, from the lowest: compounds 2 and 3 (each within the scatter of the next); then compound 1. At a limit, above all of these: compound 4.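

Within the data shown here, on the aromatic nitrogen of the shared core, 3,4-difluorophenyl in place of 4-chlorophenyl gives the first comparison that differs in a single place, read in this assay as an at least 1.1-fold higher number from compound 1 to compound 4 (0.07 log units; that floor lies within the scatter). Compound 4 carries a limit and not a number, and the step has only a floor because of that limit: the limit of > 20000 nM in this assay, at which 1 of the 4 values shown sits. With the 2-methylphenyl group and the rest of the molecule unchanged, the pair shows that this exchange on the aromatic nitrogen does not lead to a lower number, so the loss of the chlorine and the entry of two fluorines bring no higher toxicity in this test here.

From the compounds shown here alone, whether compound 4 truly stands apart from compound 1 remains open, as the floor of the step lies within the scatter and the size of any real gap cannot be read. Also open, going by these compounds, is how this position responds to other groups on the aromatic nitrogen, such as an unsubstituted phenyl, a pyridine ring or a phenyl bearing a carboxylic acid, and whether the same exchange gives the same result on a longer chain.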